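Side-chain exchange from compound 1 to compound 3

The compounds below may be only part of what the source reports. "The series", "measured", "known", "first", "only" and "open" are said of these compounds alone.

Measured so far in a functional assay on the whole organism (stomach) with Rattus norvegicus as the target; a higher number here means that more compound is needed for the effect, a lower number that less compound is needed:
- compound 1 `CCCCCCC/N=C(\S)C1(c2ccccn2)CCCS1` gives > 30 mg/kg as a limit
- compound 2 `CCCCCCCCCCCC/N=C(\S)C1(c2ccccn2)CCCS1` gives > 30 mg/kg as a limit

Compound 1 has only a limit in this assay, > 30 mg/kg, and no number. Within the data shown here, the series so far consists of the limit of > 30 mg/kg in this assay, at which 2 of the 2 values shown sit, and nothing else.

The next compound is compound 3 `CN(C)CC/N=C(\S)C1(c2ccccn2)CCCS1`. The change is dimethylamino in place of pentyl on a saturated chain carbon, two bonds along the chain from a double-bonded nitrogen; in words, dimethylamino in place of pentyl on a saturated chain carbon, two bonds along the chain from a double-bonded nitrogen. Cut one bond further out, it reads heptyl to 2-(dimethylamino)ethyl.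

Among the measured compounds shown here, the one measured step, a step that the two limits leave unreadable from compound 1 to compound 2, has no readable size and concerns a different group. For the measured compounds named here, no measured step brings in dimethylamino, so no direction can be carried over. The expectation therefore rests on compound 2, which gives > 30 mg/kg, also a limit. No step beyond the scatter is expected, and a reading that again stops at a limit is likely.

The expected step is a number no higher from compound 1 to compound 3 (the limit leaves the size open), with no direction favoured. For compound 3 the estimate is 30 mg/kg, with an expected range from 10 mg/kg to 90 mg/kg as its ends.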

Compound 3, dose for half-maximal effect: > 30 mg/kg
Compound 3 ended at the assay's limit (the forecaster's own chance of this, stated with the estimate: 65%); the middle value sits exactly at the limit.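

In this assay, among these compounds, compound 3 gives > 30 mg/kg, which is a limit and not a number, so no step from compound 1 to compound 3 can be read. The compounds shown leave open whether any side chain on the shared core gives an actual number in this assay, as the series so far reads: the limit of > 30 mg/kg in this assay, at which 3 of the 3 values shown sit.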